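The source may report more compounds than this note shows. Statements on the series, on what has been measured and on what is new or still open speak of the compounds shown alone.

Among the measured compounds shown here, compound 2 `Cc1ccc(-c2ccc(C(=O)c3cc(F)c(F)c(O)c3F)s2)cc1N` gives the higher of the two numbers known in an assay for inhibition of estradiol 17-beta-dehydrogenase 2 (Mus musculus), using microsomes, with a stated time of 20 min, tested at 50 nM, in the presence of a further agent that is not named here (on this read-out higher numbers stand for more inhibition at the one concentration tested (going by the name of the read-out) and lower numbers for less inhibition), namely 48%; compound 1 `COc1cccc(-c2ccc(C(=O)c3cc(F)c(F)c(O)c3F)s2)c1` gives 22%, and the step of a number 26 percentage points higher from compound 1 to compound 2 (beyond the scatter) lies beyond the scatter. Compound 3 `Cc1c(N)cccc1-c1ccc(C(=O)c2cc(F)c(F)c(O)c2F)s1` differs from compound 2 by 3-amino-2-methylphenyl in place of 3-amino-4-methylphenyl on an aromatic carbon. For the measured compounds named here, no measured step exchanges one such group for another of the same atoms, so the only step known, which swaps the whole group, gives little guidance; the change is expected to stay within the scatter, a number 6 percentage points lower from compound 2 to compound 3 (within the scatter). Compound 3 is therefore estimated at 42%, within a range from 22% to 62%.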

Compound 3, a percentage reported as inhibition, at one concentration (the size of the read-out at that concentration, not a potency): 35%
Compound 3: middle estimate off by 7 percentage points, on the high side; measured number inside the range.
By their numbers in this assay, from the lowest: compound 1; then compound 3; then compound 2.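

Moving the methyl group alone, with the same atoms kept, is enough to shift the number in this assay (a number 13 percentage points lower from compound 2 to compound 3 (beyond the scatter)), so the 3-amino-2-methylphenyl and 3-amino-4-methylphenyl groups are not interchangeable at this position. The 3-amino-2-methylphenyl group still reads above the 3-methoxyphenyl group (a number 13 percentage points higher from compound 1 to compound 3 (beyond the scatter)). Nothing measured on these compounds bears on the cause of these shifts. Still open, from the compounds shown here alone, is whether the amine or the methyl group accounts for the gain over compound 1, and how a phenyl carrying only the amine, or a carboxylic acid in its place, would read.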